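Swapping an ester for trifluoromethyl on an aryl urea

A few compounds are considered here, and "the series" means these few. Any claim that something is new, unique, unknown or untested is made for them only; others in the source may bear on it.

Measured so far in a functional assay on L1210 cells (Mus musculus) for inhibition, read by MTT assay; a higher number here means a weaker inhibitor, a lower number a stronger inhibitor:
- compound 1 `CCOC(=O)c1ccc(NC(=O)N2CC2C#N)cc1` gives 9700 nM
- compound 2 `N#CC1CN1C(N)=O` gives > 90000 nM, which is a limit of the assay and not a number
- compound 3 `N#CC1CN1C(=O)Nc1cccc2ccccc12` gives 2500 nM

Compound 1 stands at the highest of the two numbers in this assay; compound 3 sits at a lower number, and that gap lies beyond the usual scatter. Compound 2 gives only a limit: the limit of > 90000 nM in this assay, at which 1 of the 3 values shown sits.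

Compound 4 `N#CC1CN1C(=O)Nc1ccc(C(F)(F)F)cc1` has not yet been measured. It differs from compound 1 in one place: trifluoromethyl in place of ethoxycarbonyl on an aromatic carbon. Within the data shown here, no measured pair shows such a swap, so the size of the step in this assay cannot be read from the data. I expect a change within or close to the usual scatter, with no strong push in either direction. Compound 4 is therefore expected to land at 7000 nM, between 2500 nM and 20000 nM. The expected step is a 1.4-fold lower number from compound 1 to compound 4 (0.14 log units; within the scatter).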

Compound 4, half-maximal inhibitory concentration: 7100 nM
The estimate for compound 4 lay 1.0-fold (0.01 log units) below the measured number; low and high end bracket the measured number.
By their numbers in this assay, from the lowest: compound 3; then compounds 4 and 1 (each within the scatter of the next). At a limit, above all of these: compound 2.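

Among these compounds, until now no pair of compounds showed what a change at this aromatic carbon does. In this assay the exchange of ethoxycarbonyl for trifluoromethyl gives the first reading (a 1.4-fold lower number from compound 1 to compound 4 (0.14 log units; within the scatter)), so a group with 0 hydrogen-bond acceptors can stand where one with 2 stood, and in this pair those acceptors are not needed to hold the number. Nothing measured here explains why the two groups give numbers so close together.

On these data alone, whether an amine or a carboxylic acid on the same aromatic carbon would also hold the number remains open. A single pair also cannot tell whether a longer chain there, such as a butyl group, would fit the same picture, or whether plain hydrogen would do just as well.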